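This account rests on a few compounds, and the source may have more. Where it says the series, first, only, none or still open, it means among the compounds named here.

Compound 2 `N#Cc1ccc(SCc2ccc(Cl)cc2)cc1` gives 531 nM in an assay on microsomes for inhibition of Amine oxidase [flavin-containing] B (Homo sapiens), read by fluorescence and spectrophotometry, with a stated time of 20 min (a lower number here means a stronger inhibitor, a higher number a weaker inhibitor), the lowest of the two numbers measured; compound 1 `N#Cc1ccc(SCc2ccccc2)cc1` gives 1580 nM. Compound 3 `N#Cc1ccc(SCc2ccc(F)cc2)cc1` differs from compound 2 in one place: fluoro in place of chloro on an aromatic carbon. Within the data shown here, the only measured step, a 3.0-fold lower number from compound 1 to compound 2 (0.47 log units; beyond the scatter), concerns adding a chloro where hydrogen stood, so it bears only indirectly here, suggesting that a smaller halogen at the same place may return part of that gain. The estimate for compound 3 is therefore a modest rise, a 1.9-fold higher number from compound 2 to compound 3 (0.27 log units; within the scatter), giving 1000 nM with a range from 400 nM to 2500 nM.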

Compound 3, half-maximal inhibitory concentration: 449 nM
Compound 3: middle estimate off by 2.2-fold (0.35 log units), on the high side; low and high end bracket the measured number.
By their numbers in this assay, from the lowest: compounds 3 and 2 (each within the scatter of the next); then compound 1.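

Swapping chloro for fluoro gives a 1.2-fold lower number from compound 2 to compound 3 (0.07 log units; within the scatter), so at this place on the ring the two halogens cannot be told apart. Fluoro in place of hydrogen gives a 3.5-fold lower number from compound 1 to compound 3 (0.55 log units; beyond the scatter), which shows that the gain seen with chloro is not unique to that halogen. Nothing measured here explains why the two halogens match. Still open, from the compounds shown here alone, is whether the gain extends beyond halogens, for example to a methoxy group, a trifluoromethyl group or an amine at this place. Also open, going by these compounds, is how bromo would compare with chloro and fluoro.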